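Trading trifluoromethoxy for methyl on compound 1

This account rests on a few compounds, and the source may have more. Where it says the series, first, only, none or still open, it means among the compounds named here.

In an in vitro ADME assay on microsomes (Homo sapiens) for metabolic stability (a higher number here means that the compound lasts longer, a lower number that the compound disappears faster), compound 1 `CCc1nc(-c2ccc(OC(F)(F)F)cc2OC)c(CC)nc1NC(CC)CC` gives 0.217 h as the lowest of three measured numbers. Compound 2 `CCc1nc(NC(CC)CC)cnc1-c1ccc(Cl)cc1Cl` gives 0.467 h and compound 3 `CCc1nc(-c2ccc(OC(F)(F)F)cc2OC)c(OC)nc1NC(CC)CC` gives 0.867 h in the same test. Compound 4 `CCc1nc(-c2ccc(C)cc2OC)c(CC)nc1NC(CC)CC` has methyl in place of trifluoromethoxy on an aromatic carbon of compound 1 (methyl in place of trifluoromethoxy on an aromatic carbon). Among the measured compounds shown here, no measured step makes this swap. The nearest evidence is a 4.0-fold higher number from compound 1 to compound 3 (0.60 log units; beyond the scatter) for methoxy in place of ethyl on an aromatic carbon, but that change lies elsewhere on the molecule and says little here. The expected change is therefore none beyond the scatter, with a 1.1-fold lower number from compound 1 to compound 4 (0.06 log units; within the scatter) as the estimate in this assay. Compound 4 is estimated at 0.19 h with 0.09 h to 0.4 h as the expected range.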

Compound 4, half-life: 0.183 h
Compound 4: the middle estimate sits 1.0-fold (0.02 log units) above what was measured; the measured number falls inside the stated range.
By their numbers in this assay, from the lowest: compounds 4 and 1 (each within the scatter of the next); then compounds 2 and 3 (each within the scatter of the next).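

In this assay, replacing trifluoromethoxy, with its five heavy atoms, by methyl, with one, on the aromatic carbon para to a large group gives a 1.2-fold lower number from compound 1 to compound 4 (0.07 log units; within the scatter), so the two compounds cannot be told apart. Among the compounds shown here, the earlier step lay elsewhere on the molecule, so this is the only reading at this position. No measurement shown offers an explanation for this match. Open questions are whether an amine or a carboxylic acid here would also match, and whether this swap would give the same result on compound 3.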